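The source may hold more compounds than are shown below. What is called first, only, known or untested is meant among the compounds shown, and "the series" means these compounds.

Measured so far:
compound 1, `O=[N+]([O-])/C=C(\NC1CCCCCC1)NS(=O)(=O)c1cnccc1NC1CCCCCCC1`: 2.59
compound 2, `O=[N+]([O-])/C=C(\NC1CCCCCCC1)NS(=O)(=O)c1cnccc1NC1CCCCC1`: 2.27
compound 3, `O=[N+]([O-])/C=C(\NC1CCCCCCC1)NS(=O)(=O)c1cnccc1NC1CCCCCC1`: 2.57

In a physicochemical assay for lipophilicity (a lower number here means a more polar compound, a higher number a more lipophilic compound), compound 2 gives the lowest of the three numbers; compound 3 lies within the scatter of it, and compound 1 lies beyond the scatter above it. Compound 4, `O=[N+]([O-])/C=C(\NC1CCCCC1)NS(=O)(=O)c1cnccc1NC1CCCCC1`, has not been measured. Compared with compound 2 it differs in one place: cyclohexyl in place of cyclooctyl on an amine nitrogen. Within the data shown here, the only measured step that touches a ring of this kind, a number 0.30 log units higher from compound 2 to compound 3 (within the scatter), added one carbon to a ring on the aromatic nitrogen. Removing two carbons from the ring on the amine nitrogen is therefore expected to lower the number in this assay, by a step of roughly a number 0.50 log units lower from compound 2 to compound 4 (beyond the scatter). For compound 4 the expected value in this assay is 1.77, between 1.4 and 2.2.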

Compound 4, partition coefficient: 1.67
For compound 4 the middle estimate is 0.10 log units above the measured one, and the stated range covers the measured number.
By their numbers in this assay, from the lowest: compound 4; then compounds 2, 3 and 1 (each within the scatter of the next, the first and the last beyond it).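

In this assay the change from cyclooctyl to cyclohexyl on an amine nitrogen gives a number 0.60 log units lower from compound 2 to compound 4 (beyond the scatter) and is the only step shown at this position. It lies beyond the scatter, while a number 0.30 log units higher from compound 2 to compound 3 (within the scatter) on the nitrogen on the aromatic ring lies within it. No evidence bears on what lies behind this step.

Going by these compounds, the step is read only with cyclohexyl on the aromatic ring's nitrogen, so its size with other groups there remains open. Also open, on these data alone, is how cyclopentyl, a longer open chain or a ring carrying a carboxylic acid would read at this amine nitrogen.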